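Swapping nitro for fluoro on the series' aromatic ring

A few compounds are considered here, and "the series" means these few. Any claim that something is new, unique, unknown or untested is made for them only; others in the source may bear on it.

Compound 1 `COC(=O)c1ccc(CN(CCCc2c(N)nc(N)nc2O)c2cc(F)cc(F)c2[N+](=O)[O-])cc1` and compound 2 `COC(=O)c1ccc(CN(CCCc2c(N)nc(N)nc2O)c2cc(F)c([N+](=O)[O-])cc2[N+](=O)[O-])cc1` share the same core and were tested in a functional assay on CCRF-CEM cells (Homo sapiens) for cytotoxicity, in the absence of a further agent; a higher number here means a weaker inhibitor, a lower number a stronger inhibitor. Compound 1 reads > 100000 nM as a limit of the assay. Going by the values given here, compound 2 gives 4300 nM as the only number so far. Compound 3 `COC(=O)c1ccc(CN(CCCc2c(N)nc(N)nc2O)c2cc(F)c(F)cc2[N+](=O)[O-])cc1` differs from compound 2 by fluoro in place of nitro on an aromatic carbon in the form of fluoro in place of nitro on an aromatic carbon. For compound 1, also without a second nitro group, the limit > 100000 nM suggests that weaker inhibition beyond the scatter should be expected. The expected step of a 5.8-fold higher number from compound 2 to compound 3 (0.76 log units; beyond the scatter) is an estimate. For compound 3 the estimated value is 25000 nM within an expected range of 6000 nM to 100000 nM.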

Compound 3, half-maximal inhibitory concentration: 66000 nM
Compound 3: the middle estimate sits 2.6-fold (0.42 log units) below what was measured, within the range that was stated.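

Going by these compounds alone, at the position para to a large group, fluoro in place of nitro gives a 15-fold higher number from compound 2 to compound 3 (1.19 log units; beyond the scatter), the first reading of this change at a single place, and a large one. Moving a fluoro group on the nitrophenyl ring gives only an at least 1.5-fold lower number from compound 1 to compound 3 (0.18 log units; that floor lies within the scatter), so no order can be set between these two arrangements: the limit of > 100000 nM in this assay, at which 1 of the 3 values shown sits.

The compounds shown leave open how a nitrile, an amine or a plain hydrogen at this position would compare with nitro and fluoro. They also leave open whether the large step holds with a carboxylic acid in place of the methyl ester.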